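Swapping a Sulfonamide Arm for a Methoxyphenyl Group

The compounds below may be only part of what the source reports. "The series", "measured", "known", "first", "only" and "open" are said of these compounds alone.

Compound 1 `Cc1ccc(S(=O)(=O)NCc2cn(C[C@H](O)[C@H]3OC(=O)C(OCc4ccccc4)=C3OCc3ccccc3)nn2)cc1` is one of two compounds in this set with a numerical result in a functional assay on MCF7 cells (Homo sapiens) for antiproliferative activity, read by MTT assay, with a stated time of 72 h (a higher number here means a weaker inhibitor, a lower number a stronger inhibitor), and compound 1 gives 6400 nM, the highest of the two numbers shown. Its nearest neighbour is compound 2 `O=C1O[C@H]([C@@H](O)Cn2cc(CNS(=O)(=O)c3ccc(Cl)cc3F)nn2)C(OCc2ccccc2)=C1OCc1ccccc1`, which in this assay gives 3390 nM and differs only in the group on the sulfonyl sulfur, 4-chloro-2-fluorophenyl in place of 4-methylphenyl; the step of a 1.9-fold lower number from compound 1 to compound 2 (0.28 log units; within the scatter) stays within the scatter. Compound 3 `O=C1O/C(=C\Cn2cc(-c3ccc(Br)cc3)nn2)C(OCc2ccccc2)=C1OCc1ccccc1`, which differs from the others in more than one place, returns in this assay only a limit, > 100000 nM.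

Compound 4 `COc1ccccc1-c1cn(C[C@H](O)[C@H]2OC(=O)C(OCc3ccccc3)=C2OCc2ccccc2)nn1` is not yet measured. It arises from compound 1 by the change (2-methoxyphenyl in place of (((4-methylphenyl)sulfonyl)amino)methyl on an aromatic carbon). Among the measured compounds shown here, none of the measured steps touches this position, so the only measured step, the exchange on the sulfonyl sulfur from compound 1 to compound 2, does not speak to it. The sole result in this assay for a compound carrying an aryl group at that position is the limit of > 100000 nM in this assay, at which 1 of the 3 values shown sits, although that compound also differs elsewhere. On that basis compound 4 is expected to give a weaker result, with an estimated step of a 2.3-fold higher number from compound 1 to compound 4 (0.37 log units; beyond the scatter) and an estimated value of 15000 nM, ranging from 4000 nM to 60000 nM.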

Compound 4, half-maximal inhibitory concentration: > 100000 nM
Compound 4: only a limit was reported; the forecaster's own chance of this, stated with the estimate: 20%; middle value at least 6.6-fold (0.82 log units) from the limit.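

Among the compounds shown here, the exchange on this aromatic carbon of the five-membered ring is the first single change in the set to move the result beyond the scatter: in this assay it gives an at least 15-fold higher number from compound 1 to compound 4 (1.19 log units; beyond the scatter). For the compounds shown here, the only earlier step, on the sulfonyl sulfur, had stayed within the scatter and said nothing about whether the (((4-methylphenyl)sulfonyl)amino)methyl arm itself mattered, whereas replacing the whole arm with 2-methoxyphenyl leaves compound 4 with only a limit. Compound 3 also carries an aryl group at this position but differs elsewhere, while compound 4 keeps the rest of compound 1, so the link between an aryl group here and a result at the limit no longer depends on a compound with other changes: the limit of > 100000 nM in this assay, at which 2 of the 4 values shown sit.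

The compounds shown do not tell which part of the departing arm counts, since the sulfonyl group, the hydrogen on its nitrogen, the methylene link and the 4-methylphenyl ring all leave together. From the compounds shown here alone, it also stays open whether a carboxamide in place of the sulfonamide, a simple aminomethyl group or a benzyl group on this carbon would give a numerical result in this assay.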